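This account rests on a few compounds, and the source may have more. Where it says the series, first, only, none or still open, it means among the compounds named here.

Compound 2, `CC(C)Cc1ccc(C(C)c2nnc3n2N=C(c2ccc(C(F)(F)F)cc2)CS3)cc1`, is one of two compounds in the series with a number in a functional assay on MCF7 cells (Homo sapiens) for inhibition, read by sulforhodamine B assay, with a stated time of 72 h; on this read-out lower numbers stand for stronger inhibition and higher numbers for weaker inhibition; in this assay compound 2 gives 4200 nM. Its nearest neighbour is compound 1, `COc1ccc(C2=Nn3c(nnc3C(C)c3ccc(-c4ccccc4)c(F)c3)SC2)cc1`, which in this assay gives 2600 nM, a value that lies within the usual scatter of that of compound 2. Compound 3, `CC(c1ccc(-c2ccccc2)c(F)c1)c1n[nH]c(=S)n1N`, in this assay gives "not active" (no number reported), without a number. Compound 4, `CC(C)Cc1ccc(C(C)c2nnc3n2N=C(c2ccc([N+](=O)[O-])cc2)CS3)cc1`, differs from compound 2 in one place: nitro in place of trifluoromethyl on an aromatic carbon. For the measured compounds named here, no measured pair shows this change, so it is expected to shift the read-out little, if at all, beyond the scatter. Compound 4 is therefore expected to give about 4000 nM in this assay, between 1500 nM and 12000 nM. The step this estimate implies, a 1.1-fold lower number from compound 2 to compound 4 (0.02 log units; within the scatter), is expected to stay within the scatter.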

Compound 4, half-maximal inhibitory concentration: "not active" (no number reported)
Compound 4 has no reported number here, so the estimate cannot be set against anything.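

In this assay, for the compounds shown here, compound 4 has no number, and no step from compound 2 to compound 4 can be read. The compounds shown leave open how 4-nitrophenyl compares with 4-(trifluoromethyl)phenyl on this core, and nothing available bears on this result.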